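The compounds below may be only part of what the source reports. "The series", "measured", "known", "first", "only" and "open" are said of these compounds alone.

Measured so far:
compound 1, `CCOc1ccc(-c2cc(C(=O)O)nn2-c2ccccc2)cc1` — 3260 nM
compound 2, `CC(C)COc1ccc(-c2cc(C(=O)O)nn2-c2ccccc2)cc1` — 7420 nM

Among the compounds with values here, in an assay for displacement of a labelled ligand from E3 ubiquitin-protein ligase Mdm2 (Homo sapiens), read by fluorescence polarization, with a stated time of 30 min (on this read-out higher numbers stand for weaker inhibition and lower numbers for stronger inhibition), compound 2 stands at the higher of the two numbers, with compound 1 as its only neighbour; the two are separated by a 2.3-fold higher number from compound 1 to compound 2 (0.36 log units; beyond the scatter). Compound 3, `O=C(O)c1cc(-c2ccc(OCc3ccccc3)cc2)n(-c2ccccc2)n1`, has not yet been measured. It differs from compound 2 by phenyl in place of isopropyl on a saturated chain carbon bound to an oxygen on an aromatic ring. Within the data shown here, the one measured step that bears on this change is a 2.3-fold higher number from compound 1 to compound 2 (0.36 log units; beyond the scatter), where enlarging the group on the same saturated chain carbon bound to an oxygen on an aromatic ring brought a modestly higher number. The change to compound 3 enlarges that position again, though with a ring rather than a chain, so a step of similar size in the same direction, or none beyond the scatter, is expected in this assay. For compound 3 the estimated value is 9000 nM, with a range from 3500 nM to 25000 nM. This corresponds to an expected step of a 1.2-fold higher number from compound 2 to compound 3 (0.08 log units; within the scatter).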

Compound 3, inhibition constant: 19800 nM
Compound 3: the middle estimate sits 2.2-fold (0.34 log units) below what was measured; the measured number falls inside the stated range.
By their numbers in this assay, from the lowest: compound 1; then compound 2; then compound 3.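

In this assay, the phenyl on the saturated chain carbon bound to an oxygen on an aromatic ring continues the direction seen with isopropyl, now with a ring in place of a branched chain (a 2.7-fold higher number from compound 2 to compound 3 (0.43 log units; beyond the scatter)). Replacing methyl with phenyl at this carbon gives the widest step of the three compounds (a 6.1-fold higher number from compound 1 to compound 3 (0.78 log units; beyond the scatter)), and each larger group shown brings a higher number, with no compound going against that order. Nothing given here explains why the number rises with this change.

The compounds shown cannot separate the presence of a ring from the number of atoms added, which a cyclohexyl group or a longer straight chain at this carbon could address. They also leave open whether an amine on the added phenyl would change the direction of the step.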